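The source may report more compounds than this note shows. Statements on the series, on what has been measured and on what is new or still open speak of the compounds shown alone.

Measured compounds:
- compound 1 `O=C(Nc1ccc(Oc2ccc(-c3nccs3)cc2)cc1)Nc1ccc(Cl)c([N+](=O)[O-])c1`: 77.1%
- compound 2 `O=C(Nc1ccc(Cl)cc1)Nc1ccc(Oc2ccc(-c3ncc[nH]3)cc2)cc1`: 8.86%
- compound 3 `O=C(Nc1ccccc1)Nc1ccc(Oc2ccc(-c3ncc[nH]3)cc2)cc1`: 7.09%

In a functional assay on A549 cells (Homo sapiens) for inhibition, read by MTT assay and WST assay, with a stated time of 72 h, tested at 10 uM (on this read-out higher numbers stand for more inhibition of growth at the one concentration tested and lower numbers for less inhibition of growth), compound 3 gives 7.09%, the lowest of the three numbers; compound 2 stands nearest with 8.86%, within the scatter, and compound 1 stands furthest with 77.1%, beyond it. Compound 4 `O=C(Nc1ccc(Oc2ccc(-c3ncc[nH]3)cc2)cc1)Nc1ccc(Cl)c([N+](=O)[O-])c1` arises from compound 3 by the change (4-chloro-3-nitrophenyl in place of phenyl on an amide-type nitrogen). Within the data shown here, no measured step isolates this exact change. Among the measured compounds shown here, the one single-place step, a number 1.8 percentage points lower from compound 2 to compound 3 (within the scatter), concerns the chloro alone and stays within the scatter, so a chloro on its own gives no reason to expect movement. Compound 1 carries the same 4-chloro-3-nitrophenyl group as compound 4 but differs from it in another part of the molecule, so its high number cannot be assigned to that group alone. The expectation is therefore a rise for compound 4 in this assay, of uncertain size, a number 37.9 percentage points higher from compound 3 to compound 4 (beyond the scatter). Compound 4 is estimated at 45%, with a range from 10% to 80%.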

Compound 4, percent growth inhibition at one concentration: 12.4%
Beside the measured number, compound 4's estimate is 32.6 percentage points above it; measured number inside the range.
By their numbers in this assay, from the lowest: compounds 3, 2 and 4 (each within the scatter of the next); then compound 1.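

With the 1H-imidazol-2-yl group held constant in this assay, 4-chloro-3-nitrophenyl in place of phenyl on the amide-type nitrogen gives a number 5.3 percentage points higher from compound 3 to compound 4 (within the scatter), and nitro in place of hydrogen on an aromatic carbon gives a number 3.5 percentage points higher from compound 2 to compound 4 (within the scatter), so neither change moves the number beyond the scatter. The large difference lies at the other place: 1H-imidazol-2-yl in place of 1,3-thiazol-2-yl on an aromatic carbon gives a number 64.7 percentage points lower from compound 1 to compound 4 (beyond the scatter), which ties the high number of compound 1 to the 1,3-thiazol-2-yl group in the presence of 4-chloro-3-nitrophenyl. No available evidence bears on the reason for either result.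

The compounds shown leave open whether the 1,3-thiazol-2-yl group keeps a high number with phenyl or 4-chlorophenyl on the amide-type nitrogen. Also open, on these data alone, is what a carboxylic acid or an amine would give in place of either ring at that aromatic carbon.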